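Hydroxy on the ring of compound 3

This account rests on a few compounds, and the source may have more. Where it says the series, first, only, none or still open, it means among the compounds named here.

In a functional assay on Lu1 cells (Homo sapiens) for cytotoxicity, read by colorimetric assay and neutral red uptake, with a stated time of 72 h (a lower number here means a stronger inhibitor, a higher number a weaker inhibitor), compound 3 `CO[C@@H](C(=O)N[C@@H]1CCCCNC1=O)[C@H](O)[C@@H](O)[C@H](O)/C=C/C(C)(C)C` gives 500 nM, the lower of the two actual numbers in the series. Compound 1 `CO[C@@H](C(=O)N[C@H]1CCCCNC1=O)[C@H](O)[C@@H](O)[C@H](O)/C=C/C(C)(C)C` gives 4300 nM. Compound 2 `CO[C@@H](C(=O)N[C@H]1CCCCNC1=O)[C@@H]1OC(C)(C)O[C@H](/C=C/C(C)(C)C)[C@@H]1O` reads > 150000 nM, which is a limit of the assay and not a number.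

Compound 4 `CO[C@@H](C(=O)N[C@@H]1CC[C@@H](O)CNC1=O)[C@H](O)[C@@H](O)[C@H](O)/C=C/C(C)(C)C` carries one change relative to compound 3: hydroxy in place of hydrogen on a saturated ring carbon. This is hydroxy in place of hydrogen on a saturated ring carbon, two ring bonds from the ring nitrogen.

Going by the values given here, the only measured step at this ring is an 8.6-fold lower number from compound 1 to compound 3 (0.93 log units; beyond the scatter), and it comes with the fact that compounds 1 and 3 differ only in the configuration as drawn. Among the compounds with values here, that step shows that this assay can respond to a change at the ring, but no measured step adds a group there. Its size therefore gives only a loose guide, and the estimate stays anchored on compound 3 at 500 nM. The expected result is a small upward move, possibly within the scatter, written as a 1.3-fold higher number from compound 3 to compound 4 (0.11 log units; within the scatter). For compound 4 the estimated value is 650 nM, with an expected range of 130 nM to 3200 nM.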

Compound 4, half-maximal inhibitory concentration: 17200 nM
Compound 4: middle estimate off by 26-fold (1.42 log units), on the low side, and the stated range ends below it.
By their numbers in this assay, from the lowest: compound 3; then compound 1; then compound 4. At a limit, above all of these: compound 2.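

Adding hydroxy on this saturated ring carbon, two ring bonds from the ring nitrogen, moves the number sharply in this assay (a 34-fold higher number from compound 3 to compound 4 (1.54 log units; beyond the scatter)), so this ring also responds to a single added group. Until now the only readable response at the ring was a change in drawn configuration: the fact that compounds 1 and 3 differ only in the configuration as drawn. Compound 4 also sits above the weaker ring configuration (a 4.0-fold higher number from compound 1 to compound 4 (0.60 log units; beyond the scatter)), although that step spans the configuration difference at the ring atom that bears a large group as well as the added hydroxy.

Going by these compounds, whether the loss belongs to hydroxy itself or to any group on this carbon stays open, and a methoxy, a fluorine or an amine there would separate the two. On these data alone, the opposite configuration at the hydroxy-bearing carbon also remains open.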